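Replacing pyridin-4-yl on the shared core: working notes

A few compounds are considered here, and "the series" means these few. Any claim that something is new, unique, unknown or untested is made for them only; others in the source may bear on it.

Values so far in a functional assay on MKN-45 cells (Homo sapiens) for antiproliferative activity, read by CellTiter-Glo, with a stated time of 3 days (a lower number here means a stronger inhibitor, a higher number a weaker inhibitor), for two compounds
- compound 1 `CC(Oc1c(N)ncc2c(-c3cnn(C4CCNCC4)c3)coc12)c1c(Br)ccc(F)c1Cl` gives 510 nM as its value
- compound 2 `C[C@@H](Oc1c(N)ncc2c(-c3ccncc3)coc12)c1c(Cl)ccc(F)c1Cl` gives 900 nM as its value

Compound 2 lies within the scatter of compound 1, so neither ranks ahead of the other. Compound 3 `COC(=O)N1CC=C(c2coc3c(O[C@H](C)c4c(Cl)ccc(F)c4Cl)c(N)ncc23)CC1` has a group of 10 heavy atoms (7 carbon, 1 nitrogen, 2 oxygen; one six-membered non-aromatic ring with 1 hetero atom) in place of a group of 6 heavy atoms (5 carbon, 1 nitrogen; one six-membered aromatic ring with 1 hetero atom), on an aromatic carbon as its difference from compound 2. Among the measured compounds shown here, no measured pair shows a step at this place, so the expectation is weak: a small move toward a weaker inhibitor, not clearly beyond the scatter. The expected change is a 1.7-fold higher number from compound 2 to compound 3 (0.22 log units; within the scatter) in this estimate. The estimated value for compound 3 is 1500 nM with 400 nM to 5000 nM as its range.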

Compound 3, half-maximal inhibitory concentration: 850 nM
Compound 3: middle estimate off by 1.8-fold (0.25 log units), on the high side, and the stated range covers the measured number.
By their numbers in this assay, from the lowest: compounds 1, 3 and 2 (each within the scatter of the next).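

In this assay, among the compounds shown here, putting the larger non-aromatic six-membered ring group in place of pyridin-4-yl gives a 1.1-fold lower number from compound 2 to compound 3 (0.02 log units; within the scatter), the only step that can be read at this place. For this pair, an aromatic ring at this carbon is therefore not needed to keep the number in this range, and the added heavy atoms leave it within the scatter. No available measurement accounts for this result.

From the compounds shown here alone, it remains open whether a carboxylic acid, a simple primary amine or a single methyl at this place would move the number beyond the scatter.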